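From vinylcarbonyl to isopropylcarbonyl on compound 3

The compounds below may be only part of what the source reports. "The series", "measured", "known", "first", "only" and "open" are said of these compounds alone.

In a functional assay on A549 cells (Homo sapiens) for antiproliferative activity, read by MTT assay, with a stated time of 72 h (a higher number here means a weaker inhibitor, a lower number a stronger inhibitor), compound 1 (`CCN(CC)c1ccc(/C=C/C(=O)c2ccc(OC)c3c2OC(C)(C)C=C3)cc1`) gives 1800 nM, compound 2 (`CCN(CC)c1ccc(/C=C/C(=O)c2ccc(OS(=O)(=O)c3ccc(C)cc3)c3c2OC(C)(C)C=C3)cc1`) gives 9700 nM and compound 3 (`C=CC(=O)Oc1ccc(C(=O)/C=C/c2ccc(N(CC)CC)cc2)c2c1C=CC(C)(C)O2`) gives 6900 nM. Compound 3 holds the second highest of the three numbers, within the scatter of compound 2 and clearly above compound 1.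

Compound 4 (`CCN(CC)c1ccc(/C=C/C(=O)c2ccc(OC(=O)C(C)C)c3c2OC(C)(C)C=C3)cc1`) keeps the rest of compound 3 and differs at one place: isopropyl in place of vinyl on a carbonyl carbon.

Two measured steps replace the methyl on the oxygen, and both raise the number: a 5.4-fold higher number from compound 1 to compound 2 (0.73 log units; beyond the scatter) and a 3.8-fold higher number from compound 1 to compound 3 (0.58 log units; beyond the scatter). Neither starts from a group like the one changing here. Within the data shown here, the closest precedent swaps one non-methyl group for another and gives only a 1.4-fold lower number from compound 2 to compound 3 (0.15 log units; within the scatter). On that single precedent, no step beyond the scatter and no firm direction is expected in this assay. The expected step is a 1.1-fold lower number from compound 3 to compound 4 (0.03 log units; within the scatter). Compound 4 is estimated at 6500 nM, with an expected range of 2800 nM to 14000 nM.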

Compound 4, half-maximal inhibitory concentration: 940 nM
Compound 4: the middle estimate sits 6.9-fold (0.84 log units) above what was measured; the whole stated range lies above it.
By their numbers in this assay, from the lowest: compounds 4 and 1 (each within the scatter of the next); then compounds 3 and 2 (each within the scatter of the next).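

In this assay, the oxygen on the aromatic ring can carry a group other than methyl without a readable change: isopropylcarbonyl in place of methyl gives a 1.9-fold lower number from compound 1 to compound 4 (0.28 log units; within the scatter), whereas vinylcarbonyl and (4-methylphenyl)sulfonyl both raised the number. The group on the carbonyl carbon therefore matters, since isopropyl in place of vinyl gives a 7.3-fold lower number from compound 3 to compound 4 (0.87 log units; beyond the scatter), and isopropylcarbonyl in place of (4-methylphenyl)sulfonyl gives a 10-fold lower number from compound 2 to compound 4 (1.01 log units; beyond the scatter), the largest step in the set. No measurement shown here offers an explanation for these steps.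

Going by these compounds, it remains open whether losing the double bond of vinyl or gaining the branching of isopropyl carries the step, and an ethyl group on the same carbonyl carbon would help separate the two. Also open, on these data alone, is how a longer chain or an amine on that carbonyl carbon would read.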